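Mirror image of a sulfonamide cyclopropane

The compounds below may be only part of what the source reports. "The series", "measured", "known", "first", "only" and "open" are said of these compounds alone.

Two compounds share one core, each measured in a functional assay on the whole organism with Mus musculus as the target, with stated times of 60 min and 30 min, at a dose of 10 mg/kg by the oral route; on this read-out higher numbers stand for more inhibition at the one dose given (going by the name of the read-out) and lower numbers for less inhibition. Compound 1 `Cc1ccc(F)cc1NC[C@@H]1[C@@H](c2ccc(S(N)(=O)=O)cc2)C1(C)C` gives 10% in this assay. Compound 2 `Cc1cc(F)c(F)cc1NC[C@@H]1[C@@H](c2ccc(S(N)(=O)=O)cc2)C1(C)C` gives 15% in this assay. Within the data shown here, the one measured step, a number 5 percentage points higher from compound 1 to compound 2 (within the scatter), adds a fluoro in place of a hydrogen on an aromatic carbon. Compound 2 therefore stands highest of the two numbers, with compound 1 nearest, though the gap between them is within the scatter, so no order between them can be read.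

Compound 3 `Cc1cc(F)c(F)cc1NC[C@H]1[C@H](c2ccc(S(N)(=O)=O)cc2)C1(C)C` has not been measured in this assay. It differs from compound 2 in this way: the two compounds have the same atoms and bonds and differ only in configuration as drawn: 2 of 2 stereo elements differ (all stereocentres are inverted: mirror images); a stereocentre at a saturated ring carbon is drawn R in compound 2 and S in compound 3; a stereocentre at a saturated ring carbon is drawn R in compound 2 and S in compound 3. Among the measured compounds shown here, no measured step bears on a change of this kind; the one step recorded concerns a fluoro and is itself within the scatter. The numbers give no guide to the size or direction of the step, so the estimate can only be wide. Compound 3 is expected to give about 20% in this assay, between 0% and 55%. The expected step is a number 5 percentage points higher from compound 2 to compound 3 (within the scatter), with wide uncertainty.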

Compound 3, a percentage reported as inhibition, in the whole organism at one dose (the size of the read-out at that dose, not a potency): -5%
For compound 3 the middle estimate is 25 percentage points above the measured one; the measured number lies below the stated range.
By their numbers in this assay, from the lowest: compound 3; then compounds 1 and 2 (each within the scatter of the next).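

In this assay, inverting both stereocentres gives a number 20 percentage points lower from compound 2 to compound 3 (beyond the scatter), the first step among these compounds that lies beyond the scatter. The change can be tied to configuration alone, because nothing else separates the pair: the fact that compounds 2 and 3 differ only in the configuration as drawn. Among these compounds, the earlier fluoro step, a number 5 percentage points higher from compound 1 to compound 2 (within the scatter), stayed within the scatter, so only this mirror-image pair shows that the read-out can tell apart two forms of the shared core, with the form drawn in compound 2 giving the higher number.

On these data alone, this rests on a single pair at a single dose, so it remains open whether inverting just one of the two stereocentres would be enough, and whether the mirror image of compound 1 would move the same way. As far as these compounds go, it is also open whether the same preference would hold with a carboxylic acid in place of the sulfonamide, and the read-out gives no potency for either form, nor any reason why the configuration matters.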